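The compounds below may be only part of what the source reports. "The series", "measured", "known", "first", "only" and "open" are said of these compounds alone.

Of the compounds shown here, three with a shared core have been tested in an assay on membranes from CHO cells for displacement of a labelled ligand from adenosine receptor A1 (Homo sapiens), read by scintillation counting, with a stated time of 60 min, tested at 1 uM; a higher number here means more inhibition at the concentration tested (going by the name of the read-out), a lower number less inhibition. Compound 1 `CC1=C(C(=O)C2CC2)C(c2ccco2)NC(=O)N1` gives 2%, compound 2 `CCC(CC)OC(=O)C1=C(C)NC(=O)NC1c1ccco1` gives 2%, and compound 3 `CC1=C(C(=O)OC2CCCC2)C(c2ccco2)NC(=O)N1` gives 1%; all three sit within the scatter of one another, so compound 3 cannot be set apart from the rest. Compound 4 `CC1=C(C(=O)OCC2CC2)C(c2ccco2)NC(=O)N1` differs from compound 3 by cyclopropylmethyl in place of cyclopentyl on an oxygen next to a carbonyl group. The closest comparison is a number 1 percentage points lower from compound 2 to compound 3 (within the scatter), also a change on the oxygen next to a carbonyl group; the two steps on a carbonyl carbon, no change at the digits printed from compound 1 to compound 2 (within the scatter) and a number 1 percentage points lower from compound 1 to compound 3 (within the scatter), were equally flat. A step of a number 1 percentage points higher from compound 3 to compound 4 (within the scatter) is therefore expected in this assay, nothing beyond the scatter. Compound 4 is estimated to give 2%, within a range from 0% to 10%.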

Compound 4, a percentage reported as inhibition, at one concentration (the size of the read-out at that concentration, not a potency): 29%
For compound 4 the middle estimate is 27 percentage points below the measured one; the measured number lies above the stated range.
By their numbers in this assay, from the lowest: compounds 3, 1 and 2 (each within the scatter of the next); then compound 4.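

On an oxygen next to a carbonyl group, the choice of group can change this read-out: cyclopropylmethyl in place of cyclopentyl gives (a number 28 percentage points higher from compound 3 to compound 4 (beyond the scatter)), and in place of pentan-3-yl gives (a number 27 percentage points higher from compound 2 to compound 4 (beyond the scatter)). Cyclopropylmethoxy in place of cyclopropyl on a carbonyl carbon gives a similar step (a number 27 percentage points higher from compound 1 to compound 4 (beyond the scatter)). Nothing here explains why this group stands apart.

Still open, as far as these compounds go, is whether the three-membered ring matters, or whether a butyl chain or cyclobutylmethyl on that oxygen would behave the same way.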